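Aryl replacement at the quinolinone six-position in the antiproliferative series

This account rests on a few compounds, and the source may have more. Where it says the series, first, only, none or still open, it means among the compounds named here.

Measured compounds:
- compound 1, `O=C(Nc1cc(F)cc(F)c1)c1cc(=O)[nH]c2cc(C(F)(F)F)ccc12`: 14200 nM
- compound 2, `O=C(Nc1cc(F)cc(F)c1)c1cc(=O)[nH]c2cc(O)ccc12`: > 20000 nM
- compound 3, `O=C(Nc1cccc(F)c1)c1cc(=O)[nH]c2cc(-c3ccsc3)ccc12`: 5100 nM

In a functional assay on KYSE-70 cells for antiproliferative activity against KYSE-70 cell line (Homo sapiens), read by MTT assay, with a stated time of 72 h (a lower number here means a stronger inhibitor, a higher number a weaker inhibitor), compound 1 gives 14200 nM. The value of compound 2 in this assay, > 20000 nM, is a limit of the assay and not a number, as also stated in the limit of > 20000 nM in this assay, at which 1 of the 3 values shown sits. For the measured compounds named here, the one measured step is an at least 1.4-fold higher number from compound 1 to compound 2 (0.14 log units; that floor lies within the scatter), which does not reach beyond the scatter. Compound 3 stands lowest of the two numbers in this assay, with compound 1 the nearest, at a higher number that lies beyond the scatter.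

Compound 4, `Cc1cc(-c2ccc3c(C(=O)Nc4cccc(F)c4)cc(=O)[nH]c3c2)c(C)cc1F`, is not yet measured. It differs from compound 3 by 4-fluoro-2,5-dimethylphenyl in place of thiophen-3-yl on an aromatic carbon. Going by the values given here, no measured step touches this exchange: the step from compound 1 to compound 2 alters the same position but with groups unrelated to either aryl ring here, so it gives no direction. The step of a 1.3-fold lower number from compound 3 to compound 4 (0.11 log units; within the scatter) is therefore expected to stay within the scatter, with wide uncertainty. In this assay compound 4 is estimated at 4000 nM, in the range 1000 nM to 16000 nM.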

Compound 4, half-maximal inhibitory concentration: > 20000 nM
Compound 4 ended at the assay's limit; the forecaster's own chance of this, stated with the estimate: 10%; middle value at least 5.0-fold (0.69 log units) from the limit.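

In this assay, the exchange of thiophen-3-yl for 4-fluoro-2,5-dimethylphenyl gives an at least 3.9-fold higher number from compound 3 to compound 4 (0.59 log units; beyond the scatter); the identity of the aryl ring at this position therefore matters, which the earlier step between two non-aryl groups could not show. Compound 4 gives > 20000 nM, which is a limit of the assay and not a number. The step is therefore a floor, and its full size stays unknown: the limit of > 20000 nM in this assay, at which 2 of the 4 values shown sit.

The exchange alters ring size, adds two methyl groups and adds a fluorine at once, and the compounds shown do not separate these changes. Also open, on these data alone, is how this position responds to a plain phenyl ring, or to a phenyl ring carrying an amine or a carboxylic acid, on the same core.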